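Aryl Swap at the Limit of Detection

The compounds below may be only part of what the source reports. "The series", "measured", "known", "first", "only" and "open" are said of these compounds alone.

Going by the values given here, the three compounds measured so far share one core and differ in the aryl group on it and in the anilide. In an assay on HL-60 cells for agonist activity at N-formyl peptide receptor 3 (Homo sapiens), read by calcium flux (on this read-out higher numbers stand for an effect only at larger amounts of compound and lower numbers for an effect already at smaller amounts), compound 1 `COc1cccc(Cc2ccnn(CC(=O)Nc3ccc(Br)cc3)c2=O)c1` gives 14600 nM. Compound 2 `COc1cccc(Cc2cc(-c3cccs3)nn(CC(=O)Nc3ccc(F)cc3)c2=O)c1` reaches only the limit of this assay, reported as > 50000 nM. Compound 3 `COc1ccc(Cc2cc(-c3ccc(Cl)cc3)nn(CC(=O)Nc3ccc(Br)cc3)c2=O)cc1` likewise reaches only a limit, recorded as > 50000 nM. Compound 2 therefore stands together with compound 3 at the limit of > 50000 nM in this assay, at which 2 of the 3 values shown sit, while compound 1 alone yields a number in this assay.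

Compound 4 `COc1cccc(Cc2cc(-c3ccc(C)cc3)nn(CC(=O)Nc3ccc(F)cc3)c2=O)c1` has not yet been measured. It differs from compound 2 in one place: 4-methylphenyl in place of thiophen-2-yl on an aromatic carbon. Among the compounds with values here, no pair of measured compounds differs in only this one place, so no measured step describes the exchange. Both measured compounds carrying an aromatic group at this position, compound 2 and compound 3, sit at the limit, whereas compound 1 without such a group gives a number. On that basis compound 4 is expected to show a step that the limit leaves unreadable from compound 2 to compound 4 from its parent, that is, none beyond the scatter. The estimated value for compound 4 in this assay is 60000 nM, within 20000 nM to 200000 nM, and it may well again be reported only as a limit.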

Compound 4, half-maximal effective concentration: > 50000 nM
Compound 4: no number, only a limit; the forecaster's own chance of this, stated with the estimate: 75%; the middle value does not contradict the limit.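

Compound 2 and compound 4 each give only a limit in this assay, so no step can be read for 4-methylphenyl in place of thiophen-2-yl. The compounds shown leave open how far these two groups differ in this assay, and whether any compound carrying an aromatic group at this place would give a number there.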